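A nitro-to-amino swap at the assay limit

The source may hold more compounds than are shown below. What is called first, only, known or untested is meant among the compounds shown, and "the series" means these compounds.

Compound 1 (`CNc1ccc(-c2cn3c(OC)cc(OC)nc3n2)cc1`) gives > 100000 nM in a functional assay on LoVo cells (Homo sapiens) for antiproliferative activity, read by MTT assay, with a stated time of 72 h (a higher number here means a weaker inhibitor of growth, a lower number a stronger inhibitor of growth), and this is a limit of the assay, not a number. Compound 2 (`Cc1ccc2nc(-c3ccc([N+](=O)[O-])cc3)cn2c1`) gives > 100000 nM as well, again only a limit. Compound 2 thus stands at the limit of > 100000 nM in this assay, at which 2 of the 2 values shown sit, with no number of its own.

Compound 3 (`Cc1ccc2nc(-c3ccc(N)cc3)cn2c1`) has amino in place of nitro on an aromatic carbon, para to a large group. Among the compounds with values here, no two measured compounds differ in one place, so the size of this change can only be expected, not read from a measured step. In this assay a modest strengthening of growth inhibition is expected, an estimated at least 1.2-fold lower number from compound 2 to compound 3 (0.09 log units; that floor lies within the scatter) that may not clear the limit. That caution rests on compound 2, whose > 100000 nM is a limit. For compound 3 the estimated value is 80000 nM, with an expected range from 20000 nM to 150000 nM in this assay.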

Compound 3, concentration for 50% growth inhibition: 65200 nM
The estimate for compound 3 lay 1.2-fold (0.09 log units) above the measured number; the range from low to high includes it.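

Within the data shown here, compound 3 is the only one of the three compounds with a number in this assay, so amino in place of nitro, on an aromatic carbon para to a large group, gives a value that is not a limit at this position. The change reads as an at least 1.5-fold lower number from compound 2 to compound 3 (0.18 log units; that floor lies within the scatter). That step is a floor and not a full size, and it starts from a limit for compound 2: the limit of > 100000 nM in this assay, at which 2 of the 3 values shown sit.

As far as these compounds go, how far the true gap runs stays open, since the floor alone cannot settle it. Also open, from the compounds shown here alone, is whether amino itself matters or other groups in place of nitro on this carbon, such as a methylamino group, a hydroxyl or an acetamide, would give a similar reading.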